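Halogen swap on two methylsulfonyl anilino-imidazoline isomers

The source may hold more compounds than are shown below. What is called first, only, known or untested is meant among the compounds shown, and "the series" means these compounds.

Of the compounds shown here, three have been measured in a functional assay for agonist activity at Alpha-1A adrenergic receptor (Homo sapiens); on this read-out higher numbers stand for larger maximal responses and lower numbers for smaller maximal responses. Compound 1 `CS(=O)(=O)c1ccc(F)cc1NCC1=NCCN1` gives 96%. Compound 3 `CS(=O)(=O)c1ccc(Cl)cc1NCC1=NCCN1` differs from compound 1 by chloro in place of fluoro on an aromatic carbon. In this assay compound 3 gives 91%; the step is a number 5 percentage points lower from compound 1 to compound 3 (within the scatter). Compound 2 `CS(=O)(=O)c1cc(F)ccc1NCC1=NCCN1` gives 61%, the lowest of the three numbers, with both other values beyond the scatter above it. Compound 2 and compound 1 are built from the same atoms joined differently; the difference between the two cores is not broken down here.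

Compound 4 `CS(=O)(=O)c1cc(Cl)ccc1NCC1=NCCN1` is not yet measured. It differs from compound 2 by chloro in place of fluoro on an aromatic carbon. This is the same kind of change as that from compound 1 to compound 3, not the same: in compound 1 the site is meta to a group of 7 heavy atoms and para to a methylsulfonyl group, whereas in compound 2 it is meta to a methylsulfonyl group and para to a group of 7 heavy atoms.

The step expected for compound 4 is a number 3 percentage points lower from compound 2 to compound 4 (within the scatter), resting on the small and within-scatter step a number 5 percentage points lower from compound 1 to compound 3 (within the scatter). Among the compounds with values here, since only that one pair shows the change, and on a differently arranged core, the range is kept wide. Compound 4 is thus expected to give 58% in this assay, between 42% and 74%.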

Compound 4, largest response reached (reported as maximum), in percent of the reference or control that the assay uses: 41%
Estimate against measurement, compound 4: 17 percentage points above; the measured number lies below the stated range.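

In this assay, the swap of fluoro for chloro does not carry from one core to the other as a fixed step: the same change on two cores in this assay, a number 5 percentage points lower (within the scatter) from compound 1 to compound 3 and a number 20 percentage points lower (beyond the scatter) from compound 2 to compound 4, 15 percentage points apart, beyond the scatter of two such steps On the core of compound 2, where the site is meta to a methylsulfonyl group and para to a group of 7 heavy atoms, the swap gives a number 20 percentage points lower from compound 2 to compound 4 (beyond the scatter), so the step read on the core of compound 1 is no safe guide to the size of the step here. Within the data shown here, with one pair per core, this shows only that the two steps differ for these four compounds; it sets no rule for other halogens or other cores, and it gives no reason for the gap.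

Still open, on these data alone, is whether a methoxy group, a nitrile or an amine at the same site, on either core, would follow the small step or the larger one. Also open, as far as these compounds go, is how either halogen pair would read with a carboxylic acid or a longer chain in place of the methylsulfonyl group.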